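The source may report more compounds than this note shows. Statements on the series, on what has been measured and on what is new or still open speak of the compounds shown alone.

Of the compounds shown here, three built on one shared core have been tested in a functional assay on L1210 cells (Mus musculus); on this read-out lower numbers stand for stronger inhibition and higher numbers for weaker inhibition. Compound 1 `CCCCCCc1cn([C@H]2C[C@@H]3OP(=O)(O)OC[C@H]3O2)c(=O)[nH]c1=O` carries a hexyl chain; in this assay compound 1 gives > 500 ug/mL, which is a limit of the assay and not a number. Compound 2 `CCCc1cn([C@H]2C[C@@H]3OP(=O)(O)OC[C@H]3O2)c(=O)[nH]c1=O` gives > 500 ug/mL in this assay, again a limit. Compound 3 `CC(C)c1cn([C@H]2C[C@@H]3OP(=O)(O)OC[C@H]3O2)c(=O)[nH]c1=O`, the starting point here, gives > 500 ug/mL, also a limit. So compound 3 stands where every measured compound stands: the limit of > 500 ug/mL in this assay, at which 3 of the 3 values shown sit. The steps among them, a step that the two limits leave unreadable from compound 1 to compound 2, a step that the two limits leave unreadable from compound 1 to compound 3 and a step that the two limits leave unreadable from compound 2 to compound 3, therefore cannot be read in size or in direction. Compound 4 `CCCCCc1cn([C@H]2C[C@@H]3OP(=O)(O)OC[C@H]3O2)c(=O)[nH]c1=O` differs from compound 3 by pentyl in place of isopropyl on an aromatic carbon. The two steps that bear on this change, a step that the two limits leave unreadable from compound 1 to compound 3 and a step that the two limits leave unreadable from compound 2 to compound 3, are both unreadable, so nothing beyond the scatter can be expected in this assay in either direction, and the outcome most likely is once more only a limit. The estimate for compound 4 is 600 ug/mL, in the range 300 ug/mL to 2000 ug/mL, which means an expected step that the limit leaves unreadable from compound 3 to compound 4.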

Compound 4, concentration for 50% inhibition: > 500 ug/mL
Compound 4 was reported as a limit; the forecaster's own chance of this, stated with the estimate: 85%; the middle value does not contradict the limit.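

The steps from compound 4 to compound 1, compound 2 and compound 3 cannot be read, as each value in this assay is only a limit: the limit of > 500 ug/mL in this assay, at which 4 of the 4 values shown sit. The compounds shown leave open whether any chain on the shared core gives a measurable inhibition, and how chain length or branching would bear on it.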